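Methyl Added to the Weaker Bis-dithiocarbamate Ketone

The compounds below may be only part of what the source reports. "The series", "measured", "known", "first", "only" and "open" are said of these compounds alone.

Two compounds share the same chain, which carries two dithiocarbamate groups and a ketone, and differ only in the aromatic part attached to the ketone. Compound 1 `CN(C)C(=S)SCC(CSC(=S)N(C)C)C(=O)c1csc2ccccc12` gives 850 nM in a functional assay on NCI-H460 cells (Homo sapiens) for inhibition, read by MTT assay, with a stated time of 72 h; on this read-out higher numbers stand for weaker inhibition and lower numbers for stronger inhibition. Compound 2 `CN(C)C(=S)SCC(CSC(=S)N(C)C)C(=O)c1cnc2ccccn12` gives 13000 nM in this assay: the higher of the two numbers, and the gap to compound 1 is beyond the usual scatter, so compound 2 is the weaker inhibitor of the pair. Compound 3 `Cc1nc2ccccn2c1C(=O)C(CSC(=S)N(C)C)CSC(=S)N(C)C` has not yet been measured. It differs from compound 2 by methyl in place of hydrogen on an aromatic carbon. Among the measured compounds shown here, no pair of measured compounds differs by such a small addition, so there is no measured step to lean on. A change of this size is expected to give a step of a 1.3-fold lower number from compound 2 to compound 3 (0.11 log units; within the scatter), within the scatter. Compound 3 is therefore estimated at 10000 nM, with a range from 3000 nM to 40000 nM.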

Compound 3, half-maximal inhibitory concentration: 151000 nM
Estimate against measurement, compound 3: 15-fold (1.18 log units) below, outside the stated range (above it).
By their numbers in this assay, from the lowest: compound 1; then compound 2; then compound 3.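

In this assay, methyl in place of hydrogen gives a 12-fold higher number from compound 2 to compound 3 (1.07 log units; beyond the scatter), so inhibition becomes clearly weaker. The earlier compounds shown here showed only that exchanging the whole aromatic part matters; this result shows that even one added carbon, on the aromatic carbon next to the ring atom that bears a large group, can make a large difference in the weaker series. No measurement given here explains why this step is so large.

From the compounds shown here alone, whether an ethyl group, a fluorine atom or an amine on this carbon would weaken inhibition as much as methyl remains open. So does whether a methyl group on the core of compound 1 would produce a step of similar size.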